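Working notes on a small series in a cell assay

The source may report more compounds than this note shows. Statements on the series, on what has been measured and on what is new or still open speak of the compounds shown alone.

Measured in a functional assay on MCF7 cells (Homo sapiens) for inhibition, read by MTT assay; on this read-out lower numbers stand for stronger inhibition and higher numbers for weaker inhibition:
compound 1 `COc1ccccc1N1CCN(CC(=O)Nc2ccc(C(=O)/C=C/c3cn(Cc4ccc(Br)cc4)nn3)cc2)CC1`: 36800 nM
compound 2 `CCCCCCCCn1cc(/C=C/C(=O)c2ccc(NC(=O)CN3CCN(c4ccc([N+](=O)[O-])cc4)CC3)cc2)nn1`: 49100 nM
compound 3 `O=C(CN1CCN(c2ccc([N+](=O)[O-])cc2)CC1)Nc1ccc(C(=O)/C=C/c2cn(Cc3ccc(Br)cc3)nn2)cc1`: 31600 nM

Compound 3 and compound 1 differ by 2-methoxyphenyl in place of 4-nitrophenyl on an amine nitrogen in a ring; the step is a 1.2-fold higher number from compound 3 to compound 1 (0.07 log units; within the scatter). Compound 2 differs from compound 3 in its core by heptyl in place of 4-bromophenyl on a saturated chain carbon bound to an aromatic nitrogen, and the step is a 1.6-fold lower number from compound 2 to compound 3 (0.19 log units; within the scatter). All three values sit within the scatter of one another, so no order among them can be read.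

Compound 4 `CCCCCCCCn1cc(/C=C/C(=O)c2ccc(NC(=O)CN3CCN(c4ccccc4OC)CC3)cc2)nn1` has not yet been measured. It differs from compound 2 by 2-methoxyphenyl in place of 4-nitrophenyl on an amine nitrogen in a ring. For the measured compounds named here, the place of this change is word for word the one at which compound 3 became compound 1, so it is the same change made on the core of compound 2.

For compound 4 the expected step is a 1.1-fold higher number from compound 2 to compound 4 (0.05 log units; within the scatter), resting on the observation that a 1.2-fold higher number from compound 3 to compound 1 (0.07 log units; within the scatter) stayed within the scatter. In this assay compound 4 is estimated at 55000 nM, with a likely range from 25000 nM to 120000 nM; the number is uncertain and the assay may report only a limit at this level.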

Compound 4, half-maximal inhibitory concentration: 30000 nM
Estimate against measurement, compound 4: 1.8-fold (0.26 log units) above; the measured number falls inside the stated range.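

In this assay, putting 2-methoxyphenyl in place of 4-nitrophenyl on the core of compound 2 gives a 1.6-fold lower number from compound 2 to compound 4 (0.21 log units; within the scatter), and putting heptyl in place of 4-bromophenyl gives a 1.2-fold lower number from compound 1 to compound 4 (0.09 log units; within the scatter). The 2-methoxyphenyl change shows no difference between the two cores: the same change on two cores in this assay, a 1.2-fold higher number (0.07 log units; within the scatter) from compound 3 to compound 1 and a 1.6-fold lower number (0.21 log units; within the scatter) from compound 2 to compound 4, 1.9-fold (0.28 log units) apart, within the scatter of two such steps The same holds for the exchange of heptyl and 4-bromophenyl, but this agreement is only between steps too small to read, so it shows no effect carried from one core to the other and does not show that a larger step would carry: the same change on two cores in this assay, a 1.6-fold lower number (0.19 log units; within the scatter) from compound 2 to compound 3 and a 1.2-fold higher number (0.09 log units; within the scatter) from compound 4 to compound 1, 1.9-fold (0.28 log units) apart, within the scatter of two such steps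

The compounds shown leave open whether a carboxylic acid or an amine in place of the 2-methoxyphenyl, or a longer chain in place of the heptyl, would give a step beyond the scatter in this assay. On these data alone, whether such a step would then hold on both cores also stays open.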